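Ring Isopropyl on the Benzothiazole Core of Compound 1

A few compounds are considered here, and "the series" means these few. Any claim that something is new, unique, unknown or untested is made for them only; others in the source may bear on it.

Compound 1 `CN(O)C(=O)NCCSc1nc2ccccc2s1`: 90 nM
Compound 2 `CC(C)N(O)C(=O)NCCSc1nc2ccccc2s1`: 130 nM
Compound 3 `CN(O)C(=O)NCCSc1nc2cccc(Cl)c2s1`: 530 nM

In a functional assay for inhibition of Polyunsaturated fatty acid 5-lipoxygenase (Homo sapiens) (on this read-out higher numbers stand for an effect only at larger amounts of compound and lower numbers for an effect already at smaller amounts), compound 1 gives 90 nM, the lowest of the three numbers shown; compound 2 lies within the scatter of it, a 1.4-fold higher number from compound 1 to compound 2 (0.16 log units; within the scatter), while compound 3 stands further off, a 5.9-fold higher number from compound 1 to compound 3 (0.77 log units; beyond the scatter). Compound 4 `CC(C)c1ccc2nc(SCCNC(=O)N(C)O)sc2c1` differs from compound 1 by isopropyl in place of hydrogen on an aromatic carbon. For the measured compounds named here, of the measured steps, the one to compound 3 bears most directly, as it is the only change on the ring, although at a different place; the step to compound 2 shows that an isopropyl elsewhere changed little. A modest rise is therefore expected, a 2.8-fold higher number from compound 1 to compound 4 (0.44 log units; beyond the scatter). Compound 4 is estimated at 250 nM, with a range from 80 nM to 800 nM.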

Compound 4, half-maximal effective concentration: 160 nM
Compound 4: middle estimate off by 1.6-fold (0.19 log units), on the high side; measured number inside the range.
By their numbers in this assay, from the lowest: compounds 1, 2 and 4 (each within the scatter of the next); then compound 3.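

In this assay, isopropyl in place of hydrogen at this position gives a 1.8-fold higher number from compound 1 to compound 4 (0.25 log units; within the scatter) and so stays within the scatter. The chloro of compound 3, on a different aromatic carbon, gives a 5.9-fold higher number from compound 1 to compound 3 (0.77 log units; beyond the scatter) and lies beyond it, but group and place both differ there, so the shared core is not shown to resist every ring change. No measured evidence accounts for this result. Going by these compounds, it remains open whether an amine or a carboxylic acid on this same carbon would also stay within the scatter, and how chloro would behave here.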